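Carbonyl groups on the shared core: cyclopropyl to furan-2-yl

The compounds below may be only part of what the source reports. "The series", "measured", "known", "first", "only" and "open" are said of these compounds alone.

- Compound 1 `COc1ccc(/C=C/C(=O)c2ccc(OC)c3c2OC(C)(C)C=C3)cc1OCCCN(C)C`: 2920 nM
- Compound 2 `CCC(=O)Oc1cc(/C=C/C(=O)c2ccc(OC)c3c2OC(C)(C)C=C3)ccc1OC`: 160 nM
- Compound 3 `COc1ccc(/C=C/C(=O)c2ccc(OC)c3c2OC(C)(C)C=C3)cc1OC(=O)C1CC1`: 410 nM

In a functional assay on K562 cells (Homo sapiens) for cytotoxicity, read by MTT assay (a higher number here means a weaker inhibitor, a lower number a stronger inhibitor), compound 3 at 410 nM holds the second highest of the three numbers. Compound 4 `COc1ccc(/C=C/C(=O)c2ccc(OC)c3c2OC(C)(C)C=C3)cc1OC(=O)c1ccco1` differs from compound 3 by one change, furan-2-yl in place of cyclopropyl on a carbonyl carbon. The nearest measured precedent, at the same carbon, is a 2.6-fold higher number from compound 2 to compound 3 (0.41 log units; beyond the scatter). The larger steps, an 18-fold lower number from compound 1 to compound 2 (1.26 log units; beyond the scatter) and a 7.1-fold lower number from compound 1 to compound 3 (0.85 log units; beyond the scatter), replace 3-(dimethylamino)propyl and bear on this change only loosely. Among the measured compounds shown here, no measured compound has an aromatic ring on that carbonyl carbon, so the direction is uncertain. The expected step is small: a 1.2-fold lower number from compound 3 to compound 4 (0.07 log units; within the scatter). For compound 4 the estimated value is 350 nM, with an expected range of 120 nM to 1000 nM.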

Compound 4, half-maximal inhibitory concentration: 450 nM
Compound 4: the middle estimate sits 1.3-fold (0.11 log units) below what was measured; low and high end bracket the measured number.
By their numbers in this assay, from the lowest: compound 2; then compounds 3 and 4 (each within the scatter of the next); then compound 1.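

In this assay an aromatic ring on the carbonyl carbon gives a 1.1-fold higher number from compound 3 to compound 4 (0.04 log units; within the scatter) and so does not separate furan-2-yl from cyclopropyl. Ethyl stays apart from furan-2-yl, with a 2.8-fold higher number from compound 2 to compound 4 (0.45 log units; beyond the scatter) at the same carbon, while a 6.5-fold lower number from compound 1 to compound 4 (0.81 log units; beyond the scatter) places (furan-2-yl)carbonyl on the oxygen clear of 3-(dimethylamino)propyl. No measurement here bears on the reason for these steps. Open, going by these compounds, is whether a longer chain such as butyl on that carbonyl carbon would follow ethyl. Also open, on these data alone, is whether phenyl would read like furan-2-yl.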